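A few compounds are considered here, and "the series" means these few. Any claim that something is new, unique, unknown or untested is made for them only; others in the source may bear on it.

Going by the values given here, in an ADME assay on NIH3T3 cells (Mus musculus) for cytotoxicity, read by MTT assay, with a stated time of 72 h (on this read-out higher numbers stand for weaker inhibition and lower numbers for stronger inhibition), two compounds have numbers so far. Compound 1 (`COc1ccc(/C=C/c2cc(C)n[nH]2)cc1`) gives 19900 nM and compound 2 (`Cc1cc(/C=C/c2ccc(O)c(O)c2)on1`) gives 26200 nM, so compound 2 stands level with compound 1, within the scatter of repeated measurements. Compound 3 (`COc1cc(/C=C/c2cc(C)no2)ccc1O`) has not yet been measured in this assay. It differs from compound 2 in one place, methyl in place of hydrogen on an oxygen on an aromatic ring, which reads as hydroxy to methoxy. Among the compounds with values here, no measured pair in this small set shows such a change, so the expectation rests only on the two values in hand. No shift beyond the scatter is expected, and the estimated 1.1-fold lower number from compound 2 to compound 3 (0.04 log units; within the scatter) has no firm direction. For compound 3 the expected value is 24000 nM, with an estimated range of 10000 nM to 60000 nM.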

Compound 3, half-maximal inhibitory concentration: > 100000 nM
Compound 3 gave a limit, no number (the forecaster's own chance of this, stated with the estimate: 10%); middle value at least 4.1-fold (0.61 log units) away from the limit.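

In this assay, going by these compounds alone, the change from hydroxy to methoxy, methyl in place of hydrogen on an oxygen on an aromatic ring, is the first single-place change that can be read, and it gives an at least 3.8-fold higher number from compound 2 to compound 3 (0.58 log units; beyond the scatter). Compound 3 reads only as a limit of the assay, > 100000 nM, and not as a number. From the compounds shown here alone, this shows that the number responds to a change at this oxygen, but the full size of the step stays unknown because the reading for compound 3 stops at a limit: the limit of > 100000 nM in this assay, at which 1 of the 3 values shown sits.

Going by these compounds, whether an ethyl group on the same oxygen, or a fluorine atom in place of the hydroxy, would move the number the same way remains open. On these data alone, it is also open whether the same change would give a similar step on another core.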